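The compounds below may be only part of what the source reports. "The series", "measured", "known", "first", "only" and "open" are said of these compounds alone.

Measured in an ADME assay on Vero cells (Chlorocebus sabaeus) for cytotoxicity; on this read-out lower numbers stand for higher toxicity in this test and higher numbers for lower toxicity in this test:
- Compound 1 `CCCCCC(=O)Nc1nc(N)nc2c1ncn2[C@H]1CO[C@@H](CO)O1`: > 100000 nM (a limit)
- Compound 2 `CCCCCCCCCC(=O)Nc1nc(N)nc2c1ncn2[C@H]1CO[C@@H](CO)O1`: > 100000 nM (a limit)
- Compound 3 `CCCCCCCCCCCCCC(=O)Nc1nc(N)nc2c1ncn2[C@H]1CO[C@@H](CO)O1`: 7700 nM

Compound 3 is the only one of these with an actual number, and it is the lowest reading available, since compound 1 and compound 2 report only limits. Compound 4 `CCCCCCCCCCCCCCCC(=O)Nc1nc(N)nc2c1ncn2[C@H]1CO[C@@H](CO)O1` lengthens the chain of compound 3: ethyl in place of hydrogen on a saturated chain carbon, ten or more bonds along the chain from a carbonyl carbon. Going by the values given here, the steps that bear on this are also chain extensions. The step of an at least 12-fold lower number from compound 2 to compound 3 (1.11 log units; beyond the scatter) is large, as is the step of an at least 12-fold lower number from compound 1 to compound 3 (1.11 log units; beyond the scatter), whereas the step that the two limits leave unreadable from compound 1 to compound 2 cannot be sized. Ethyl is a smaller addition than the butyl of the step of an at least 12-fold lower number from compound 2 to compound 3 (1.11 log units; beyond the scatter), so a further but more modest fall is expected. The expected step is a 1.9-fold lower number from compound 3 to compound 4 (0.28 log units; within the scatter). For compound 4 the estimated value is 4000 nM, within an expected range of 1000 nM to 20000 nM.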

Compound 4, half-maximal cytotoxic concentration: 90000 nM
The estimate for compound 4 lay 23-fold (1.35 log units) below the measured number; the measured number lies above the stated range.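

With ethyl added in place of hydrogen on a saturated chain carbon, the direction seen earlier reverses: this assay shows a 12-fold higher number from compound 3 to compound 4 (1.07 log units; beyond the scatter). The number therefore does not keep falling as the chain grows, and compound 4 goes against the fall seen up to compound 3. The shorter chains give an at least 1.1-fold lower number from compound 2 to compound 4 (0.04 log units; that floor lies within the scatter) and an at least 1.1-fold lower number from compound 1 to compound 4 (0.04 log units; that floor lies within the scatter), so neither floor separates compound 4 from compound 1 or compound 2, whose values are limits: the limit of > 100000 nM in this assay, at which 2 of the 4 values shown sit.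

Going by these compounds, what a longer chain, or an amine in place of the ethyl, would give in this assay stays open.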